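Nitro Addition on the Shared Core: Cytotoxicity Notes

The source may report more compounds than this note shows. Statements on the series, on what has been measured and on what is new or still open speak of the compounds shown alone.

Three compounds stand measured in an ADME assay on Vero cells (Chlorocebus sabaeus) for cytotoxicity; on this read-out lower numbers stand for higher toxicity in this test and higher numbers for lower toxicity in this test. Among the compounds with values here, compound 1 `COc1ccc(-c2nc3cc(Cl)c(Cl)cc3[nH]2)cc1` gives 30000 nM in this assay, the only value in the set that is a number. For compound 3 `CC(=O)Nc1ccc(-c2nc3ccccc3[nH]2)cc1` this assay reports only a limit, > 100000 nM. For compound 2 `CC(=O)Nc1ccc(-c2nc3cc([N+](=O)[O-])ccc3[nH]2)cc1` the result is likewise a limit, > 100000 nM. The change from compound 3 to compound 2 is nitro in place of hydrogen on an aromatic carbon, and the step that the two limits leave unreadable from compound 3 to compound 2 stays unreadable because both values sit at the limit of > 100000 nM in this assay, at which 2 of the 3 values shown sit. Compound 4 `COc1ccc(-c2nc3cc(Cl)c(Cl)cc3[nH]2)c([N+](=O)[O-])c1` is unmeasured and differs from compound 1 by nitro in place of hydrogen on an aromatic carbon, the same kind of change, here ortho to a large group and meta to a methoxy group rather than meta and para to a fused ring. The difference between the cores of compound 1 and compound 3 is not broken down here. A small step is expected, a 1.3-fold higher number from compound 1 to compound 4 (0.12 log units; within the scatter). That expectation rests on compound 1 at 30000 nM alone, the measured nitro step giving no reading. Compound 4 is estimated at 40000 nM, between 15000 nM and 100000 nM.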

Compound 4, half-maximal cytotoxic concentration: 80000 nM
Compound 4: middle estimate off by 2.0-fold (0.30 log units), on the low side; measured number inside the range.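

Nitro in place of hydrogen on an aromatic carbon gives a 2.7-fold higher number from compound 1 to compound 4 (0.43 log units; beyond the scatter) in this assay, which is a single reading on a single core, with the nitro ortho to a large group and meta to a methoxy group. The step from compound 3 to compound 2 cannot be read, because both compounds sit at the same limit of the assay: the limit of > 100000 nM in this assay, at which 2 of the 4 values shown sit. Whether the change carries from one core to the other is therefore not shown, neither as a match nor as a mismatch.

Open, from the compounds shown here alone, is whether an amine or a carboxylic acid in the same place on compound 4 would move the number the same way. Also open, going by these compounds, is whether the nitro step has any readable size on the core of compound 3.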